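Amide aryl swap in a quinoline series

This account rests on a few compounds, and the source may have more. Where it says the series, first, only, none or still open, it means among the compounds named here.

Measured compounds:
- compound 1, `CCN1CCN(c2cc(C)c3cc(NC(=O)c4ccc[nH]4)ccc3n2)CC1`: 14700 nM
- compound 2, `Cc1cc(NCCN2CCN(C)CC2)nc2ccc(NC(=O)c3ccc(Cl)c(Cl)c3)cc12`: 1700 nM
- compound 3, `Cc1cc(N2CCCCC2)nc2ccc(NC(=O)c3ccc(Cl)c(Cl)c3)cc12`: 31100 nM

In a functional assay on MCF7 cells (Homo sapiens) for antiproliferative activity, read by MTT assay, with a stated time of 72 h (on this read-out lower numbers stand for stronger inhibition and higher numbers for weaker inhibition), compound 1 gives 14700 nM, the second highest of the three numbers. Its nearest neighbour is compound 3 with 31100 nM; compound 2 at 1700 nM stands furthest from it. For the measured compounds named here, the one step between compounds that differ in a single place runs an 18-fold higher number from compound 2 to compound 3 (1.26 log units; beyond the scatter), and it concerns the substituent on the aromatic carbon, not the acyl part of the amide.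

Compound 4, `CCN1CCN(c2cc(C)c3cc(NC(=O)c4ccc(Cl)cc4)ccc3n2)CC1`, is not yet measured. It differs from compound 1 by 4-chlorophenyl in place of 1H-pyrrol-2-yl on a carbonyl carbon. Going by the values given here, no measured pair changes the group on this carbonyl carbon; compound 2 and compound 3 carry a different aryl on it throughout and both differ from compound 1 elsewhere as well, so they give no direct guide. With nothing bearing on the change, no step beyond the scatter is expected, and compound 4 is estimated at 12000 nM (range 4000 nM to 36000 nM), which is expected to mean a step of a 1.2-fold lower number from compound 1 to compound 4 (0.09 log units; within the scatter).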

Compound 4, half-maximal inhibitory concentration: 1530 nM
Beside the measured number, compound 4's estimate is 7.8-fold (0.89 log units) above it, and the stated range ends above it.
By their numbers in this assay, from the lowest: compounds 4 and 2 (each within the scatter of the next); then compound 1; then compound 3.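

For the compounds shown here, with the rest of the structure unchanged, 4-chlorophenyl in place of 1H-pyrrol-2-yl on a carbonyl carbon gives in this assay a 9.6-fold lower number from compound 1 to compound 4 (0.98 log units; beyond the scatter), the only measured step at this position. The acyl part of the amide therefore moves the read-out too, whereas the earlier step concerned only the substituent on the aromatic carbon. This single pair changes ring size, the hydrogen-bond donor and the chlorine together and cannot separate them, and no measurement shown explains the step.

On these data alone, whether the chlorine or the six-membered carbon ring matters more stays open; phenyl or 4-methoxyphenyl on the same carbonyl carbon would help to separate them. Also open, as far as these compounds go, is whether the step holds with a (2-(4-methylpiperazin-1-yl)ethyl)amino group on the aromatic carbon.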